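A few compounds are considered here, and "the series" means these few. Any claim that something is new, unique, unknown or untested is made for them only; others in the source may bear on it.

Three compounds share one core, a carbon chain that ends in an oxime and a ketone and joins an aromatic ring bearing a fluorine and a bromine to a six-membered saturated ring. Compound 1 `NS(=O)(=O)N1CCC(C(=O)/C(=N/O)Nc2ccc(F)c(Br)c2)CC1` has a sulfamoyl group on the ring nitrogen. Compound 2 `O=C(/C(=N/O)Nc1ccc(F)c(Br)c1)[C@H]1CC[C@H](NS(=O)(=O)Nc2ccccc2)CC1` and compound 3 `O=C(Nc1ccccc1)[C@H]1CC[C@H](C(=O)/C(=N/O)Nc2ccc(F)c(Br)c2)CC1` carry instead a phenylsulfamoyl-amino group or a phenyl amide on a carbon ring. In an assay for inhibition of Indoleamine 2,3-dioxygenase 1 (Homo sapiens), with a stated time of 1 h (a higher number here means a weaker inhibitor, a lower number a stronger inhibitor), compound 1 gives 63 nM, compound 2 gives 102 nM, and compound 3 gives 150 nM. Of these three numbers compound 1 has the lowest; compound 2 sits within the usual scatter of it, compound 3 a little beyond.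

The step to compound 4 `O=C(/C(=N/O)Nc1ccc(F)c(Br)c1)C1CCN(C(=O)Nc2ccccc2)CC1` changes one spot: phenylcarbamoyl in place of sulfamoyl on an amine nitrogen in a ring. Going by the values given here, no measured pair shows this exact step, so the expectation rests on the neighbours. A modest rise in the number, near the edge of the scatter, is expected from compound 1 to compound 4, a 2.1-fold higher number from compound 1 to compound 4 (0.31 log units; beyond the scatter), because compound 3, which also carries a phenyl amide, gives 150 nM. Compound 4 is thus estimated at 130 nM, between 50 nM and 350 nM.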

Compound 4, half-maximal inhibitory concentration: 40 nM
Compound 4: middle estimate off by 3.3-fold (0.51 log units), on the high side; measured number below the stated range.
By their numbers in this assay, from the lowest: compounds 4, 1, 2 and 3 (each within the scatter of the next, the first and the last beyond it).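

In this assay, placing phenylcarbamoyl instead of sulfamoyl on the amine nitrogen in the ring gives a 1.6-fold lower number from compound 1 to compound 4 (0.20 log units; within the scatter) and so no real difference in the reading. This shows that the position accepts a group with 9 heavy atoms and a six-membered aromatic ring in place of one with 4 heavy atoms and no ring, and that sulfur is not needed there for a number in this range. Nothing measured here explains why these two different groups give such similar numbers.

As far as these compounds go, it remains open how far this acceptance extends, for instance to a plain methyl group, a carboxylic acid or a longer chain on the same nitrogen. The compounds shown also do not tell whether a substituent such as chlorine on the new aromatic ring would move the number.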